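The source may report more compounds than this note shows. Statements on the series, on what has been measured and on what is new or still open speak of the compounds shown alone.

In a functional assay on NALM-6 cells (Homo sapiens) for cytotoxicity, read by luminescence and CellTiter-Glo, with a stated time of 3 days (on this read-out higher numbers stand for weaker inhibition and lower numbers for stronger inhibition), compound 1 `N#Cc1cc(Cl)ccc1NC(=O)c1ccc2cccnc2c1O` gives 280 nM. Compound 3 `Cc1cc(C#N)ccc1NC(=O)c1ccc2cccnc2c1O` gives 230 nM, within the usual scatter of compound 1, while compound 2 `O=C(Nc1ccc(C(F)(F)F)cc1)c1ccc(Cl)cc1O` gives 1180 nM, a higher number beyond that scatter. Compound 1 therefore sits level with compound 3 and clearly ahead of compound 2 in inhibition.

Compound 4 `O=C(Nc1ccc(Cl)cc1)c1ccc2cccnc2c1O` differs from compound 1 in a single place, with hydrogen in place of cyano on an aromatic carbon. For the measured compounds named here, no measured pair isolates this change. Compound 3 carries a cyano group and compound 2 does not, but both also differ from compound 1 elsewhere, so they offer only a weak guide. A small rise in the number is expected, meaning slightly weaker inhibition, and it probably stays within the scatter. The estimated change is a 1.4-fold higher number from compound 1 to compound 4 (0.15 log units; within the scatter). For compound 4 the expected value is 400 nM, with an estimated range from 140 nM to 1100 nM.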

Compound 4, half-maximal inhibitory concentration: 380 nM
Compound 4: the middle estimate sits 1.1-fold (0.02 log units) above what was measured; the range from low to high includes it.
By their numbers in this assay, from the lowest: compounds 3, 1 and 4 (each within the scatter of the next); then compound 2.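

In this assay, for the compounds shown here, putting hydrogen in place of cyano on this aromatic carbon, ortho to a large group and meta to a chloro group, gives a 1.4-fold higher number from compound 1 to compound 4 (0.13 log units; within the scatter) and is the first direct reading of this change, as the earlier compounds each differ from compound 1 in more than one place. The step lies within the usual scatter, so compound 4, with no cyano group at this position, cannot be told apart from compound 1. Nothing measured here bears on why this swap leaves so little mark on the number.

As far as these compounds go, whether a different group at this position, such as an amine or a methoxy group, would shift the number beyond the scatter remains open. One step on one pair also cannot show whether the same swap would give a similar result on other compounds.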